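Methoxy Triazole Analogue: Expected Tolerability

This account rests on a few compounds, and the source may have more. Where it says the series, first, only, none or still open, it means among the compounds named here.

Measured in a functional assay on MT2 cells (Homo sapiens) for cytotoxicity, read by XTT assay, with a stated time of 3 days; a lower number here means that less compound is tolerated, a higher number that more compound is tolerated:
Compound 1 `COc1cnc(-c2ccncc2)c2[nH]cc(C(=O)C(=O)N3CCN(C(=O)c4ccccc4)CC3)c12` gives 6000 nM.
Compound 2 `CNC(=O)c1ncn(-c2ncc(OC)c3c(C(=O)C(=O)N4CCN(C(=O)c5ccccc5)CC4)c[nH]c23)n1` gives > 300000 nM, which is a limit of the assay.
Compound 3 `COc1cnc(-n2cnc(C(=O)N(C)C)n2)c2[nH]cc(C(=O)C(=O)N3CCN(C(=O)c4ccccc4)CC3)c12` gives > 300000 nM, which is a limit of the assay.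

Compound 3 therefore stands at the top of what the assay can report, together with compound 2, as shown by the limit of > 300000 nM in this assay, at which 2 of the 3 values shown sit. Compound 4 `COc1ncn(-c2ncc(OC)c3c(C(=O)C(=O)N4CCN(C(=O)c5ccccc5)CC4)c[nH]c23)n1` differs from compound 3 by methoxy in place of dimethylcarbamoyl on an aromatic carbon. Within the data shown here, no measured step changes the group on the triazole carbon in this way. The nearest step, a step that the two limits leave unreadable from compound 2 to compound 3, cannot be read because both ends are limits. The steps of an at least 50-fold higher number from compound 1 to compound 2 (1.69 log units; beyond the scatter) and an at least 50-fold higher number from compound 1 to compound 3 (1.69 log units; beyond the scatter) show that the triazolyl variants are tolerated far better than compound 1, whichever carbamoyl sits on the triazole. The methoxy variant is expected to behave like them, so the step of an at least 1.2-fold lower number from compound 3 to compound 4 (0.07 log units; that floor lies within the scatter) is expected to show nothing readable beyond the scatter. Compound 4 is estimated at 250000 nM, within 60000 nM to 600000 nM.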

Compound 4, half-maximal cytotoxic concentration: 285000 nM
Estimate against measurement, compound 4: 1.1-fold (0.06 log units) below, within the range that was stated.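

Among these compounds, compound 4 is the first triazolyl compound here with a real number rather than a limit, so the gain over the pyridin-4-yl compound can be read in full as a 48-fold higher number from compound 1 to compound 4 (1.68 log units; beyond the scatter) in this assay. A carbamoyl group on the triazole carbon between two ring nitrogen atoms is therefore not needed for this high tolerance, since methoxy, with fewer heavy atoms, serves there too. The steps of an at least 1.0-fold lower number from compound 3 to compound 4 (0.02 log units; that floor lies within the scatter) and an at least 1.0-fold lower number from compound 2 to compound 4 (0.02 log units; that floor lies within the scatter) are only floors, and both lie within the scatter, so they show no loss from this change.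

From the compounds shown here alone, whether an amine, a carboxylic acid or a longer chain on this carbon would be tolerated as well stays open. Going by these compounds, how far compound 2 and compound 3 truly lie from compound 4 also stays open, as their values are limits: the limit of > 300000 nM in this assay, at which 2 of the 4 values shown sit.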